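The compounds below may be only part of what the source reports. "The series", "measured", "known", "first", "only" and "open" are said of these compounds alone.

In an ADME assay on the whole organism (Rattus norvegicus) for pharmacokinetics, read by LC-MS, at a dose of 5 mg/kg by the oral route (a lower number here means that a smaller share of the oral dose reaches the circulation, a higher number that a larger share of the oral dose reaches the circulation), compound 1 `CNC(=O)c1c(-c2ccc(F)cc2)oc2cc(-n3nccc3-c3ccc(B(O)O)c(F)c3)c(C3CC3)cc12` gives 64%, while compound 2 `CNC(=O)c1c(-c2ccc(F)cc2)oc2cc(N(Cc3ccc(B(O)O)c(F)c3)S(C)(=O)=O)c(C3CC3)cc12` gives 23%, the lower of the two numbers and a gap beyond the scatter. Compound 3 `CNC(=O)c1c(-c2ccc(F)cc2)oc2cc(N(c3ccc(B(O)O)c(Cl)c3)S(C)(=O)=O)c(C3CC3)cc12` differs from compound 2 by a group of 10 heavy atoms (6 carbon, 1 boron, 2 oxygen, 1 chlorine; one six-membered aromatic ring of carbon only) in place of a group of 11 heavy atoms (7 carbon, 1 boron, 2 oxygen, 1 fluorine; one six-membered aromatic ring of carbon only), on a sulfonamide nitrogen. Among the compounds with values here, no measured pair shows this kind of change, so its direction cannot be read from the numbers in hand. Compound 3 is expected to move by a number 5 percentage points higher from compound 2 to compound 3 (within the scatter), a step not expected to exceed the scatter. The estimate for compound 3 is therefore 28%, within a range from 10% to 55%.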

Compound 3, oral bioavailability: 27%
Estimate against measurement, compound 3: 1 percentage points above; the measured number falls inside the stated range.
By their numbers in this assay, from the lowest: compounds 2 and 3 (each within the scatter of the next); then compound 1.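

In this assay, the exchange on the sulfonamide nitrogen gives the first step measured at this place, a number 4 percentage points higher from compound 2 to compound 3 (within the scatter) and so within the scatter. The group of 10 heavy atoms with its chlorine and the group of 11 heavy atoms with its fluorine therefore cannot be told apart by this read-out. Nothing in hand accounts for this result.

The compounds shown leave open how an amine or a carboxylic acid on this sulfonamide nitrogen would read, and whether any such group would give a step beyond the scatter.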